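Aromatic substituent variation on the shared core

This account rests on a few compounds, and the source may have more. Where it says the series, first, only, none or still open, it means among the compounds named here.

Measured compounds in a functional assay on HBL-100 cells (Homo sapiens) for inhibition, read by sulforhodamine B assay, with a stated time of 48 h; on this read-out lower numbers stand for stronger inhibition of growth and higher numbers for weaker inhibition of growth:
compound 1, `COC(=O)[C@@]1(C)CCC=C2[C@@H]1CC[C@@H](C)[C@]2(C)Cc1c(C)[nH]c2ccc(Br)cc12`, 15000 nM
compound 2, `COC(=O)[C@@]1(C)CCC=C2[C@@H]1CC[C@@H](C)[C@]2(C)Cc1c(C)[nH]c2ccc(F)cc12`, 14000 nM

Of the two numbers, compound 2 holds the lower one, but the step of a 1.1-fold lower number from compound 1 to compound 2 (0.03 log units; within the scatter) lies within the scatter, so compound 1 and compound 2 cannot be told apart on this read-out. Among the measured compounds shown here, the only change measured so far is the swap of one halogen for another on the aromatic carbon.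

Compound 3, `COC(=O)[C@@]1(C)CCC=C2[C@@H]1CC[C@@H](C)[C@]2(C)Cc1c(C)[nH]c2ccc(OC)cc12`, differs from compound 2 in one place: methoxy in place of fluoro on an aromatic carbon. For the measured compounds named here, the one measured step that bears on this position, from compound 1 to compound 2, shows that replacing the substituent on that aromatic carbon left the number unchanged within the scatter. Going by the values given here, no measured step introduces a methoxy or a hydrogen-bond acceptor at this position, so the data give no basis for a shift in either direction. For compound 3 the number in this assay is therefore expected to stay close to that of compound 2, with a step of no change at the digits printed from compound 2 to compound 3 (within the scatter). The estimate for compound 3 is 14000 nM, with a range from 6000 nM to 35000 nM.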

Compound 3, concentration for 50% growth inhibition: 16000 nM
Estimate against measurement, compound 3: 1.1-fold (0.06 log units) below; the range from low to high includes it.
By their numbers in this assay, from the lowest: compounds 2, 1 and 3 (each within the scatter of the next).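

In this assay, methoxy in place of fluoro gives a 1.1-fold higher number from compound 2 to compound 3 (0.06 log units; within the scatter), and methoxy in place of bromo gives a 1.1-fold higher number from compound 1 to compound 3 (0.03 log units; within the scatter), so compound 1, compound 2 and compound 3 cannot be told apart. Until now, this aromatic carbon had been probed only by a swap of one halogen for another; the series now includes a non-halogen group, methoxy, with 2 heavy atoms and 1 hydrogen-bond acceptor against 1 heavy atom and 0 hydrogen-bond acceptors for fluoro, and the read-out still does not separate the compounds. No accompanying data bear on why these three substituents cannot be separated.

The compounds shown leave open whether an amine, a carboxylic acid or a longer chain such as butoxy on this same aromatic carbon, or hydrogen in place of any substituent there, would give a step beyond the scatter. They also leave open whether a change elsewhere on the shared core would move the number, since all three compounds differ only at this one carbon.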